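Dropping a nitrile from a benzimidazole enzyme inhibitor

This account rests on a few compounds, and the source may have more. Where it says the series, first, only, none or still open, it means among the compounds named here.

Of the compounds shown here, three sharing one core have been tested in an assay on V79 cells for inhibition of cytochrome P450 11B1, mitochondrial (Homo sapiens), read by HTRF, with a stated time of 1 h; on this read-out higher numbers stand for weaker inhibition and lower numbers for stronger inhibition. Compound 1 `FC(F)(F)c1ccc2c(c1)nc(-c1cccnc1)n2C1CC1` carries a trifluoromethyl group on its six-membered carbon ring and gives only a limit in this assay, > 10000 nM, which is the edge of what the test can report rather than a number, (the limit of > 10000 nM in this assay, at which 1 of the 3 values shown sits). Compound 2 `N#Cc1ccc2nc(-c3cccnc3)n(C3CC3)c2c1` carries a cyano group in the corresponding region and gives 374 nM in this assay. Compound 3 `Cc1ccncc1-c1nc2cc(F)c(F)cc2n1C1CC1` has two fluorine atoms on that ring and a methyl group on its pyridine and gives 723 nM in this assay. Compound 2 has the lowest number of the two measured values, but its gap to compound 3 lies within the usual scatter of repeated measurements, so the two cannot be ranked.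

Compound 4 `c1cncc(-c2nc3ccccc3n2C2CC2)c1` is the next compound. It differs from compound 2 in one place: hydrogen in place of cyano on an aromatic carbon. Among the measured compounds shown here, no measured pair shows exactly this change, so its effect can only be estimated.

The cyano group of compound 2 is the only difference, and a bare core is expected to bind more weakly. The step expected from compound 2 to compound 4 in this assay is a 5.3-fold higher number from compound 2 to compound 4 (0.73 log units; beyond the scatter), in the direction of weaker inhibition. Compound 4 is therefore estimated at 2000 nM, with a likely range from 600 nM to 7000 nM.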

Compound 4, half-maximal inhibitory concentration: > 8330 nM
Compound 4 ended at the assay's limit; the forecaster's own chance of this, stated with the estimate: 10%; middle value at least 4.1-fold (0.61 log units) away from the limit.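

In this assay, hydrogen in place of cyano on this aromatic carbon gives an at least 22-fold higher number from compound 2 to compound 4 (1.34 log units; beyond the scatter), a large step in the direction of weaker inhibition. Among the compounds shown here, this is the first measured pair that differs only at this position, and it shows that the cyano group accounts for much of the inhibition seen with compound 2, since the bare core of compound 4 keeps everything else unchanged. Compound 1 and compound 4 both end at limits of the assay rather than at numbers, so the step between them cannot be read, and nothing can be said about how trifluoromethyl compares with hydrogen: the limit of > 8330 nM in this assay, at which 1 of the 4 values shown sits.

From the compounds shown here alone, it remains open whether the cyano group is special or whether other groups on the same aromatic carbon, such as a methoxy group, an amide or a carboxylic acid, would keep the inhibition seen with compound 2. Going by these compounds, the true size of the loss also stays open, as compound 4 gives only a limit and not a number.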